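Fluoro on the 4-cyanophenyl group of compound 2

This account rests on a few compounds, and the source may have more. Where it says the series, first, only, none or still open, it means among the compounds named here.

In an ADME assay on MT4 cells (Homo sapiens) for cytotoxicity, read by MTT assay, with a stated time of 5 days (a higher number here means that more compound is tolerated, a lower number that less compound is tolerated), compound 1 (`Cc1cc(OCC(=O)Nc2cccc(Cl)c2)nc(Nc2ccc(C#N)cc2)n1`) reads 32200 nM as a plain number. Compound 2 (`Cc1cc(OCC(=O)Nc2ccc(C#N)cc2)nc(Nc2ccc(C#N)cc2)n1`) reads > 325000 nM as a limit of the assay and not a number. Compound 2 therefore stands at the limit of > 325000 nM in this assay, at which 1 of the 2 values shown sits, with no number of its own. Compound 3 (`Cc1cc(OCC(=O)Nc2ccc(C#N)cc2F)nc(Nc2ccc(C#N)cc2)n1`) has fluoro in place of hydrogen on an aromatic carbon, ortho to a large group and meta to a cyano group, as counted in fluoro in place of hydrogen on an aromatic carbon with the rest of compound 2 unchanged. Within the data shown here, the one measured step is an at least 10-fold higher number from compound 1 to compound 2 (1.00 log units; beyond the scatter) and it exchanges the whole group on the amide-type nitrogen, so only a small fall or no change beyond the scatter is expected for compound 3. Another limit reading is also possible. The expected size of an at least 1.6-fold lower number from compound 2 to compound 3 (0.21 log units; that floor lies within the scatter) in this assay is a modest fall. Compound 3 is expected at 200000 nM within an estimated range of 50000 nM to 400000 nM on this read-out.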

Compound 3, half-maximal cytotoxic concentration: > 310000 nM
Compound 3 was reported as a limit (the forecaster's own chance of this, stated with the estimate: 55%); at least 1.5-fold (0.19 log units) between middle value and limit.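

In this assay compound 3 reads > 310000 nM, a limit of the assay and not a number. Fluoro on an aromatic carbon, ortho to a large group and meta to a cyano group, therefore leaves the reading at a limit, as with the 4-cyanophenyl group of compound 2, and the step between these two limits cannot be read. Against the 3-chlorophenyl group, the 4-cyano-2-fluorophenyl group gives an at least 9.6-fold higher number from compound 1 to compound 3 (0.98 log units; beyond the scatter), so the difference beyond the scatter also holds with fluoro present.

Going by these compounds, whether fluoro lowers the tolerated concentration at all stays open while both readings are limits. A numerical reading from a hydroxyl or an amine at this carbon, or from fluoro on another carbon of the ring, would show how far this position can change before the reading leaves the limit.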